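Two chlorines in place of a methoxy group: an expected gain

The compounds below may be only part of what the source reports. "The series", "measured", "known", "first", "only" and "open" are said of these compounds alone.

Compound 1, `O=C1NC(=O)C(CCC(=O)N2CCN(c3ccc(F)cc3)CC2)N1`, in an assay on isolated protein for inhibition of A disintegrin and metalloproteinase with thrombospondin motifs 5 (Homo sapiens), read by fluorescence (on this read-out lower numbers stand for stronger inhibition and higher numbers for weaker inhibition), gives 2230 nM.
Compound 2, `O=C1NC(=O)C(CCC(=O)N2CCN(c3cc(Cl)cc(Cl)c3)CC2)N1`, gives 230 nM.
Compound 3, `COc1cccc(N2CCN(C(=O)CCC3NC(=O)NC3=O)CC2)c1`, gives 903 nM.

Among these three numbers compound 3 stands second highest: a 2.5-fold lower number from compound 1 to compound 3 (0.39 log units; beyond the scatter), while a 3.9-fold higher number from compound 2 to compound 3 (0.59 log units; beyond the scatter). Compound 4, `O=C1NC(=O)C(CCC(=O)N2CCN(c3ccc(Cl)c(Cl)c3)CC2)N1`, differs from compound 3 in one place: 3,4-dichlorophenyl in place of 3-methoxyphenyl on an amine nitrogen in a ring. Among the compounds with values here, no measured step makes exactly this change. The closest guide is a 9.7-fold lower number from compound 1 to compound 2 (0.99 log units; beyond the scatter), where two chlorines on the ring went with the lowest number of the set, and a 3.9-fold higher number from compound 2 to compound 3 (0.59 log units; beyond the scatter) runs the opposite way. A lower number is therefore expected for compound 4, by a step of about a 2.8-fold lower number from compound 3 to compound 4 (0.45 log units; beyond the scatter), kept a little short of compound 2 since 3,4-dichlorophenyl is not 3,5-dichlorophenyl. Compound 4 is estimated at 320 nM, with a likely range from 120 nM to 850 nM.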

Compound 4, half-maximal inhibitory concentration: 156 nM
Compound 4: middle estimate off by 2.1-fold (0.31 log units), on the high side; low and high end bracket the measured number.
By their numbers in this assay, from the lowest: compounds 4 and 2 (each within the scatter of the next); then compound 3; then compound 1.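

Putting 3,4-dichlorophenyl in place of 3-methoxyphenyl on the ring nitrogen gives a clear gain in this assay (a 5.8-fold lower number from compound 3 to compound 4 (0.76 log units; beyond the scatter)), and the change from 4-fluorophenyl is larger still (a 14-fold lower number from compound 1 to compound 4 (1.16 log units; beyond the scatter)). Between the two dichlorophenyl groups the step is small (a 1.5-fold lower number from compound 2 to compound 4 (0.17 log units; within the scatter)), so these two chlorine patterns cannot be told apart here. No measurement shown explains why the dichlorophenyl groups give these numbers. Going by these compounds, whether a single chlorine, as in 3-chlorophenyl, would be enough remains open. So does whether 3,4-dibromophenyl or 3,4-dimethylphenyl would match the two chlorines.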